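From 3,4-Dimethylphenyl to 5-Chloro-2-Methylphenyl

The compounds below may be only part of what the source reports. "The series", "measured", "known", "first", "only" and "open" are said of these compounds alone.

For the measured compounds named here, in a functional assay on MCF7 cells (Homo sapiens) for antiproliferative activity, read by MTT assay, with a stated time of 72 h (a higher number here means a weaker inhibitor of growth, a lower number a stronger inhibitor of growth), compound 2 `Cc1ccc(-n2nnc(C(=O)Nc3ccc(SC#N)cc3)c2C)cc1C` gives 72000 nM, the only actual number so far. Compound 1 `Cc1c(C(=O)Nc2ccc(SC#N)cc2)nnn1-c1ccc(C(C)C)cc1` gives > 100000 nM, which is a limit and not a number. Going by the values given here, the one measured step is an at least 1.3-fold lower number from compound 1 to compound 2 (0.14 log units; that floor lies within the scatter), with 3,4-dimethylphenyl in place of 4-isopropylphenyl on an aromatic nitrogen. Compound 3 `Cc1ccc(Cl)cc1-n1nnc(C(=O)Nc2ccc(SC#N)cc2)c1C` changes that same group, with 5-chloro-2-methylphenyl in place of 3,4-dimethylphenyl (5-chloro-2-methylphenyl in place of 3,4-dimethylphenyl on an aromatic nitrogen). As that single step offers no firm size, no change beyond the scatter is expected in this assay. The expected step is a 1.0-fold lower number from compound 2 to compound 3 (0.01 log units; within the scatter). For compound 3 the estimate is 70000 nM, with an expected range of 30000 nM to 100000 nM.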

Compound 3, concentration for 50% growth inhibition: 8400 nM
Compound 3: the middle estimate sits 8.3-fold (0.92 log units) above what was measured, outside the stated range (below it).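

In this assay, the aryl group on the aromatic nitrogen proves able to move the number: 5-chloro-2-methylphenyl in place of 3,4-dimethylphenyl gives an 8.6-fold lower number from compound 2 to compound 3 (0.93 log units; beyond the scatter), although the two groups match in heavy-atom count. Replacing 4-isopropylphenyl with the same group gives an at least 11-fold lower number from compound 1 to compound 3 (1.07 log units; beyond the scatter). That size is only a floor, as compound 1 stands at a limit and not at a number: the limit of > 100000 nM in this assay, at which 1 of the 3 values shown sits.

From the compounds shown here alone, whether the chlorine or the shifted methyl carries the step remains open. So does how a methoxy group or an amine in place of that chlorine would read.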